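The compounds below may be only part of what the source reports. "The series", "measured", "known", "first", "only" and "open" are said of these compounds alone.

Compound 3 `COc1cc(O)c(C(=O)O)c(C=Cc2ccc3ccccc3c2)c1` is one of three compounds sharing a core that was measured in an ADME assay on HEK293 cells (Homo sapiens) for cytotoxicity, read by resazurin assay, with a stated time of 24 h; a higher number here means that more compound is tolerated, a lower number that less compound is tolerated; there compound 3 gives 65000 nM. Its nearest neighbour is compound 2 `O=C(O)c1c(O)cccc1C=Cc1ccc2ccccc2c1`, which in this assay gives 97000 nM; compound 1 `O=C(O)c1c(O)cc(Cl)cc1C=Cc1ccc2ccccc2c1` gives 38000 nM. Within the data shown here, compound 3 thus sits second highest of the three numbers, but both of its gaps, the one to compound 2 and the one to compound 1, lie within the usual scatter of this assay.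

Compound 4 `Cc1cc(O)c(C(=O)O)c(C=Cc2ccc3ccccc3c2)c1` has not been measured. It differs from compound 3 in one place: methyl in place of methoxy on an aromatic carbon.

Among the measured compounds shown here, no measured step exchanges methyl for methoxy. For the measured compounds named here, the steps that bear on it are those at the same position: a 1.5-fold lower number from compound 2 to compound 3 (0.17 log units; within the scatter) and a 1.7-fold higher number from compound 1 to compound 3 (0.23 log units; within the scatter), both small and within the scatter. Only a 2.6-fold higher number from compound 1 to compound 2 (0.41 log units; beyond the scatter) exceeded the scatter, and it concerns chloro, not methoxy. On that basis the step of a 1.1-fold lower number from compound 3 to compound 4 (0.03 log units; within the scatter) is expected to remain within the scatter, and compound 4 is estimated to give 60000 nM in this assay, with a range from 30000 nM to 120000 nM.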

Compound 4, half-maximal cytotoxic concentration: 52000 nM
Estimate against measurement, compound 4: 1.2-fold (0.06 log units) above; measured number inside the range.
By their numbers in this assay, from the lowest: compounds 1, 4, 3 and 2 (each within the scatter of the next, the first and the last beyond it).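

At this position, para to a carboxy group, methyl gives a 1.3-fold lower number from compound 3 to compound 4 (0.10 log units; within the scatter) and also a 1.9-fold lower number from compound 2 to compound 4 (0.27 log units; within the scatter) and then a 1.4-fold higher number from compound 1 to compound 4 (0.14 log units; within the scatter) in this assay so none of its three steps leaves the scatter. Taking away the oxygen of methoxy, with its one hydrogen-bond acceptor, is therefore not accompanied by a step beyond the scatter, and the pair of compound 1 and compound 2 remains the only one of the four compounds beyond it. Nothing available here accounts for these numbers.

On these data alone, whether an amine, a carboxylic acid or a longer chain at this position would stay within the same scatter remains open. So does the effect of any change to the hydroxy group, the carboxy group or the large group on the shared core.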